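Aryl variation on a corticotropin-releasing factor receptor 1 ligand

The source may report more compounds than this note shows. Statements on the series, on what has been measured and on what is new or still open speak of the compounds shown alone.

Measured compounds:
compound 1, `CCc1ccccc1C(Nc1ccc(Cl)cc1Cl)C(=O)CCc1ccncc1`, 330 nM
compound 2, `Cc1cccc(C)c1C(Nc1ccc(Cl)cc1Cl)C(=O)CCc1ccncc1`, 338 nM
compound 3, `Cc1cc(F)ccc1C(Nc1ccc(Cl)cc1Cl)C(=O)CCc1ccncc1`, 512 nM

Three compounds share a core and differ only in the aryl group on a saturated chain carbon bound to a carbonyl carbon and a nitrogen on an aromatic ring. In an assay on isolated protein for binding affinity to corticotropin-releasing factor receptor 1 (Homo sapiens) (on this read-out higher numbers stand for weaker inhibition and lower numbers for stronger inhibition), compound 1 gives 330 nM, compound 2 gives 338 nM and compound 3 gives 512 nM. Compound 3 shows the highest number of the three, but the step of a 1.6-fold higher number from compound 1 to compound 3 (0.19 log units; within the scatter) and the step of a 1.5-fold higher number from compound 2 to compound 3 (0.18 log units; within the scatter) are both within the scatter, as is a 1.0-fold higher number from compound 1 to compound 2 (0.01 log units; within the scatter); the three compounds are therefore indistinguishable in this assay.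

Compound 4, `O=C(CCc1ccncc1)C(Nc1ccc(Cl)cc1Cl)c1ccccc1C(F)(F)F`, has not been measured. It differs from compound 3 in that (2-(trifluoromethyl)phenyl in place of 4-fluoro-2-methylphenyl on a saturated chain carbon bound to a carbonyl carbon and a nitrogen on an aromatic ring). Among the measured compounds shown here, no measured step introduces a trifluoromethyl group, so none bears directly on this change; the three measured steps only show that exchanging one ortho-substituted aryl for another left the number within the scatter. On that basis compound 4 is expected to stay close to compound 3, with a 1.2-fold lower number from compound 3 to compound 4 (0.09 log units; within the scatter) as the estimated step. The estimate for compound 4 in this assay is 420 nM, within a range from 150 nM to 1200 nM.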

Compound 4, inhibition constant: 1000 nM
Estimate against measurement, compound 4: 2.4-fold (0.38 log units) below; measured number inside the range.
By their numbers in this assay, from the lowest: compounds 1, 2, 3 and 4 (each within the scatter of the next, the first and the last beyond it).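

In this assay (this assay), the aryl position no longer looks indifferent to exchange: 2-(trifluoromethyl)phenyl in place of 2,6-dimethylphenyl gives a step beyond the scatter (a 3.0-fold higher number from compound 2 to compound 4 (0.47 log units; beyond the scatter)), and trifluoromethyl in place of ethyl on an aromatic carbon does the same (a 3.0-fold higher number from compound 1 to compound 4 (0.48 log units; beyond the scatter)). Both steps are modest, and the exchange of 4-fluoro-2-methylphenyl for 2-(trifluoromethyl)phenyl remains within the scatter (a 2.0-fold higher number from compound 3 to compound 4 (0.29 log units; within the scatter)), so compound 4 separates from only two of the three earlier compounds. Nothing available explains these differences.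

The compounds shown leave open whether the trifluoromethyl group stands apart from other replacements for ethyl on this aromatic carbon. A chlorine, a methoxy group or a nitrile there could show whether the number stays near that of compound 1 or moves towards that of compound 4.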